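Bromo in place of fluoro on the shared core

The compounds below may be only part of what the source reports. "The series", "measured", "known", "first", "only" and "open" are said of these compounds alone.

Measured so far:
compound 1 `COc1cc(OC)c(C(=O)/C=C/c2ccccc2)c(OC)c1`: 24%
compound 2 `COc1cc(OC)c(C(=O)/C=C/c2ccc(F)cc2)c(OC)c1`: 27%

In a functional assay on PC-3 cells (Homo sapiens), read by fluorescence and BrdU incorporation, with a stated time of 48 h, tested at 10 uM (a lower number here means a stronger effect, a higher number a weaker effect of the compound at the concentration tested), compound 1 gives 24% and compound 2 gives 27%. Compound 2 holds nominally the higher of the two numbers, but the step of a number 3 percentage points higher from compound 1 to compound 2 (within the scatter) lies within the scatter, so the two are not separable. Compound 3 `COc1cc(OC)c(C(=O)/C=C/c2ccc(Br)cc2)c(OC)c1` differs from compound 2 by bromo in place of fluoro on an aromatic carbon. Among the measured compounds shown here, no measured step exchanges one halogen for another; the only step at hand, a number 3 percentage points higher from compound 1 to compound 2 (within the scatter), shows a halogen entering at this position without effect beyond the scatter. The expected step of a number 1 percentage points higher from compound 2 to compound 3 (within the scatter) is therefore none beyond the scatter. Compound 3 is estimated at 28%, between 15% and 42%.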

Compound 3, a percentage reported as activity, at one concentration (the size of the read-out at that concentration, not a potency): 35%
Compound 3: middle estimate off by 7 percentage points, on the low side; measured number inside the range.
By their numbers in this assay, from the lowest: compounds 1, 2 and 3 (each within the scatter of the next, the first and the last beyond it).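

In this assay, bromo in place of fluoro on this aromatic carbon gives a number 8 percentage points higher from compound 2 to compound 3 (within the scatter), so the two halogens remain unseparated here. Bromo in place of hydrogen gives a number 11 percentage points higher from compound 1 to compound 3 (beyond the scatter), the first step at this position beyond the scatter, although a modest one. Nothing available bears on the origin of this step.

The compounds shown leave open whether a chloro group would fall in line with the two halogens. They also leave open how a methoxy group, an amine or a carboxylic acid at this position would read out.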